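This account rests on a few compounds, and the source may have more. Where it says the series, first, only, none or still open, it means among the compounds named here.

Going by the values given here, compound 2 `CCCN(Cc1c(C(F)(F)F)nc2n(-c3c(C)cc(C)cc3C)c(Cl)cn12)CC1CCC1` holds the lower of the two numbers so far in an assay on cells for displacement of a labelled ligand from corticotropin-releasing factor receptor 1 (Homo sapiens), with a stated time of 100 min (a higher number here means a weaker inhibitor, a lower number a stronger inhibitor), giving 5.3 nM; compound 1 `C=CCN(CC=C)Cc1c(C(F)(F)F)nc2n(-c3c(C)cc(C)cc3C)c(Cl)cn12` gives 13 nM, and the step reads a 2.5-fold lower number from compound 1 to compound 2 (0.39 log units; beyond the scatter). Compound 3 `CCCN(Cc1ccc(F)cc1)Cc1c(C(F)(F)F)nc2n(-c3c(C)cc(C)cc3C)c(Cl)cn12` carries 4-fluorophenyl in place of cyclobutyl on a saturated chain carbon bound to an amine nitrogen. Among the compounds with values here, the only measured step, from compound 1 to compound 2, changed both amine substituents at once and does not address a cyclobutyl-to-aryl swap, so no step bears directly on it. For compound 3 the expectation is a change of at most modest size, a 1.5-fold higher number from compound 2 to compound 3 (0.18 log units; within the scatter), and an estimate of 8 nM with a range of 3 nM to 25 nM.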

Compound 3, inhibition constant: 350 nM
The estimate for compound 3 lay 44-fold (1.64 log units) below the measured number; measured number above the stated range.
By their numbers in this assay, from the lowest: compound 2; then compound 1; then compound 3.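

At the saturated chain carbon bound to an amine nitrogen, the series does not accept every ring: in this assay, 4-fluorophenyl in place of cyclobutyl gives a 66-fold higher number from compound 2 to compound 3 (1.82 log units; beyond the scatter), a large step. The earlier change of both amine substituents moved the number far less, with a 2.5-fold lower number from compound 1 to compound 2 (0.39 log units; beyond the scatter). Nothing available explains this loss.

On these data alone, compound 3 changes ring size, aromatic character and fluorine together, so their separate contributions remain open. An unsubstituted phenyl or a cyclohexyl at this place would help separate them.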